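Dichlorophenyl for trifluoromethylphenyl at the benzyl ether

The source may hold more compounds than are shown below. What is called first, only, known or untested is meant among the compounds shown, and "the series" means these compounds.

Measured so far:
Compound 1 `Cc1ccc(NC(=S)NC(=O)c2ccc(OCc3ccccc3)cc2)cc1-c1nc2ccccc2[nH]1` — 60700 nM
Compound 2 `Cc1ccc(NC(=S)NC(=O)c2ccc(OCc3ccc(C(F)(F)F)cc3)cc2)cc1-c1nc2ccccc2[nH]1` — 6500 nM
Compound 3 `Cc1ccc(NC(=S)NC(=O)c2ccc(OCc3cccc(C(F)(F)F)c3)cc2)cc1-c1nc2ccccc2[nH]1` — 5210 nM

All three were tested in a functional assay on MGC-803 cells (Homo sapiens) for inhibition, read by MTT assay, with a stated time of 48 h; on this read-out higher numbers stand for weaker inhibition and lower numbers for stronger inhibition. Compound 3 gives the lowest number; against compound 2 the gap is a 1.2-fold lower number from compound 2 to compound 3 (0.10 log units; within the scatter), against compound 1 it is a 12-fold lower number from compound 1 to compound 3 (1.07 log units; beyond the scatter). Compound 4 `Cc1ccc(NC(=S)NC(=O)c2ccc(OCc3cccc(Cl)c3Cl)cc2)cc1-c1nc2ccccc2[nH]1` differs from compound 3 in one place: 2,3-dichlorophenyl in place of 3-(trifluoromethyl)phenyl on a saturated chain carbon bound to an oxygen on an aromatic ring. For the measured compounds named here, the steps that bear on this are a 9.3-fold lower number from compound 1 to compound 2 (0.97 log units; beyond the scatter) and a 12-fold lower number from compound 1 to compound 3 (1.07 log units; beyond the scatter), which show that a substituent on this ring matters, and a 1.2-fold lower number from compound 2 to compound 3 (0.10 log units; within the scatter), which shows that where it sits made little difference. Because a 1.2-fold lower number from compound 2 to compound 3 (0.10 log units; within the scatter) was within the scatter, the expected step to compound 4 is a 1.0-fold lower number from compound 3 to compound 4 (0.02 log units; within the scatter), none beyond the scatter. Compound 4 is estimated at 5000 nM, between 2000 nM and 15000 nM.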

Compound 4, half-maximal inhibitory concentration: > 100000 nM
Compound 4: only a limit was reported; the forecaster's own chance of this, stated with the estimate: 5%; middle value at least 20-fold (1.30 log units) away from the limit.
By their numbers in this assay, from the lowest: compounds 3 and 2 (each within the scatter of the next); then compound 1. At a limit, above all of these: compound 4.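

Compound 4 stands at a limit of the assay rather than at a number: the limit of > 100000 nM in this assay, at which 1 of the 4 values shown sits. A substituent on this ring therefore does not lower the number by its presence alone: 2,3-dichlorophenyl gives an at least 19-fold higher number from compound 3 to compound 4 (1.28 log units; beyond the scatter) and an at least 15-fold higher number from compound 2 to compound 4 (1.18 log units; beyond the scatter), although the trifluoromethyl groups in different places gave a 1.2-fold lower number from compound 2 to compound 3 (0.10 log units; within the scatter). Against the phenyl of compound 1 only a floor is known: an at least 1.6-fold higher number from compound 1 to compound 4 (0.21 log units; that floor lies within the scatter). Still open, from the compounds shown here alone, is whether a single chlorine or a methoxy group on this ring would match trifluoromethyl.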